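The source may report more compounds than this note shows. Statements on the series, on what has been measured and on what is new or still open speak of the compounds shown alone.

Measured in a functional assay on 1321-N1 cells for agonist activity at Free fatty acid receptor 1 (Homo sapiens), read by calcium flux, with a stated time of 0.4 s; a higher number here means that more compound is needed for the effect, a lower number that less compound is needed:
- compound 1 `O=C(O)CCc1ccc(C#CC2CCCC2)cc1` — 490 nM
- compound 2 `C/C=C(/C)C#Cc1ccc(CCC(=O)O)c(F)c1` — 20.4 nM; 20 nM (2 entries)
- compound 3 `C/C=C(\C)C#Cc1ccc(CCC(=O)O)c(F)c1` — 37.2 nM

Compound 1 has the highest of the two single numbers in this assay; compound 3 sits well below it, a gap beyond the scatter, and compound 2 gives several entries that agree closely (the several entries of compound 2 in this assay, 20.4 nM; 20 nM (2 entries)). Compounds 2 and 3 differ only in the drawn configuration (the fact that compounds 2 and 3 differ only in the configuration as drawn) and lie close to each other.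

Compound 4 `C=C(C)C#Cc1ccc(CCC(=O)O)cc1` is not yet measured. Against compound 1 it carries 1-methylethenyl in place of cyclopentyl on a triple-bonded carbon. The unsaturated groups of compounds 2 and 3 go with lower numbers, though those compounds also carry a fluorine that compound 1 lacks, so the comparison is not clean. A modest fall is expected from compound 1 to compound 4 in this assay, estimated as a 2.5-fold lower number from compound 1 to compound 4 (0.39 log units; beyond the scatter). Compound 4 is expected near 200 nM, within 60 nM to 700 nM.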

Compound 4, half-maximal effective concentration: 417 nM
Compound 4: middle estimate off by 2.1-fold (0.32 log units), on the low side; the measured number falls inside the stated range.
By their numbers in this assay, from the lowest: compound 3; then compounds 4 and 1 (each within the scatter of the next).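

In this assay, 1-methylethenyl in place of cyclopentyl on a triple-bonded carbon gives a 1.2-fold lower number from compound 1 to compound 4 (0.07 log units; within the scatter), so this position accepts an open unsaturated group in place of the ring with no readable shift. The ring of compound 1 is therefore not required here for a number of this size. No measured property shown bears on why the two groups read alike.

No single-place pair shown isolates the fluorine of compounds 2 and 3. On these data alone, what an amine or a longer chain would give on the same triple-bonded carbon also stays open.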